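Compound 3 to compound 4: an expected step down

The source may report more compounds than this note shows. Statements on the series, on what has been measured and on what is new or still open speak of the compounds shown alone.

In an ADME assay for permeability, using PAMPA, at pH 7.4 (a lower number here means that the compound crosses the layer more slowly, a higher number that the compound crosses the layer faster), compound 3 (`CN(C[C@H]1Cc2c(cccc2N2CCN3CCC[C@@H]3C2)CN1)[C@H]1CCCc2cccnc21`) reaches 740 nm/s and stands highest of the three measured compounds, above compound 1 (`CN(C[C@H]1Cc2c(cccc2N2CCN(C3CC3)CC2)CN1)[C@H]1CCCc2cccnc21`) at 265 nm/s and compound 2 (`CN(C[C@H]1Cc2c(cccc2N2CCN3CCC[C@H]3C2)CN1)[C@H]1CCCc2cccnc21`) at 167 nm/s in the same read-out. Compound 4 (`C[C@@H]1CN(c2cccc3c2C[C@H](CN(C)[C@H]2CCCc4cccnc42)NC3)C[C@H](C)N1C`) keeps the shared core and changes only the group on the aromatic carbon, which becomes 3,4,5-trimethylpiperazin-1-yl (a group of 9 heavy atoms (7 carbon, 2 nitrogen; one six-membered non-aromatic ring with 2 hetero atoms) in place of a group of 9 heavy atoms (7 carbon, 2 nitrogen; one five-membered non-aromatic ring with 1 hetero atom, one six-membered non-aromatic ring with 2 hetero atoms), on an aromatic carbon). The measured steps at this carbon were a 2.8-fold higher number from compound 1 to compound 3 (0.45 log units; beyond the scatter) and a 1.6-fold lower number from compound 1 to compound 2 (0.20 log units; within the scatter) while a 4.4-fold higher number from compound 2 to compound 3 (0.65 log units; beyond the scatter) goes with the fact that compounds 2 and 3 differ only in the configuration as drawn and shows how wide the spread is even with identical atoms and bonds. Since compound 3 at 740 nm/s tops that spread, a new group on this carbon is expected to land lower, though by a modest amount. The expected change is a 2.2-fold lower number from compound 3 to compound 4 (0.34 log units; beyond the scatter). Compound 4 is estimated at 340 nm/s with an expected range from 150 nm/s to 750 nm/s in this assay when it is measured.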

Compound 4, apparent permeability: 142 nm/s
Beside the measured number, compound 4's estimate is 2.4-fold (0.38 log units) above it, outside the stated range (below it).
By their numbers in this assay, from the lowest: compounds 4, 2 and 1 (each within the scatter of the next); then compound 3.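

Placing 3,4,5-trimethylpiperazin-1-yl on the aromatic carbon gives a 5.2-fold lower number from compound 3 to compound 4 (0.72 log units; beyond the scatter), while a 1.2-fold lower number from compound 2 to compound 4 (0.07 log units; within the scatter) and a 1.9-fold lower number from compound 1 to compound 4 (0.27 log units; within the scatter) both stay within the scatter. With three different groups now grouped together in this assay, compound 3 stands alone among the four compounds at this position, rather than simply heading a spread of three. Its gap from compound 2, which has the same atoms and bonds, goes with one difference: the fact that compounds 2 and 3 differ only in the configuration as drawn.

Going by these compounds, whether a morpholine or an open-chain dimethylamino group on this carbon would join compound 3 or the other three remains open. So does whether another drawn configuration at the methyl-bearing ring carbons of the 3,4,5-trimethylpiperazin-1-yl group would move the number as far as the one change separating compound 2 from compound 3.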